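A few compounds are considered here, and "the series" means these few. Any claim that something is new, unique, unknown or untested is made for them only; others in the source may bear on it.

Measured so far:
compound 1 `COc1cc(Cl)cc(-c2nn(-c3cccc(NC(=O)c4ccc(Cl)c(Cl)c4)c3)cc2-c2ccncc2)c1` — -0.94%
compound 2 `O=C(Nc1cccc(-n2cc(-c3ccncc3)c(-c3cc(O)cc(Cl)c3)n2)c1)Nc1ccc(Cl)c(C(F)(F)F)c1` — 21.5%

In a functional assay on A498 cells (Homo sapiens) for inhibition, read by sulforhodamine B assay, with a stated time of 48 h, tested at 10 uM (on this read-out lower numbers stand for a stronger effect and higher numbers for a weaker effect at the one concentration tested), compound 1 gives -0.94%, the lowest of the two numbers, and compound 2 gives 21.5%, a difference beyond the usual scatter. Compound 3 `COc1cc(Cl)cc(-c2nn(-c3cccc(NC(=O)Nc4ccc(Cl)c(C(F)(F)F)c4)c3)cc2-c2ccncc2)c1` is not yet measured. It differs from compound 1 in one place: (4-chloro-3-(trifluoromethyl)phenyl)amino in place of 3,4-dichlorophenyl on a carbonyl carbon. Within the data shown here, no step between two measured compounds matches this change, and compound 2 carries the same entering group on a different core. The step of a number 12.9 percentage points higher from compound 1 to compound 3 (beyond the scatter) from compound 1 to compound 3 is therefore expected to run upward, toward weaker effect. Compound 3 is estimated at 12%, between -5% and 30%.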

Compound 3, a percentage reported as activity, at one concentration (the size of the read-out at that concentration, not a potency): -9.18%
For compound 3 the middle estimate is 21.2 percentage points above the measured one, outside the stated range (below it).
By their numbers in this assay, from the lowest: compounds 3 and 1 (each within the scatter of the next); then compound 2.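

In this assay, (4-chloro-3-(trifluoromethyl)phenyl)amino in place of 3,4-dichlorophenyl on a carbonyl carbon gives a number 8.2 percentage points lower from compound 1 to compound 3 (within the scatter), so this exchange leaves the read-out unchanged within the scatter. Methyl in place of hydrogen on an oxygen on an aromatic ring gives a number 30.7 percentage points lower from compound 2 to compound 3 (beyond the scatter), which locates the large step at that oxygen rather than at the carbonyl carbon. No available evidence explains either step. From the compounds shown here alone, whether an ethyl group or a longer chain on that oxygen would hold the read-out stays open, as does the effect of an unsubstituted phenyl on the carbonyl carbon.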